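A few compounds are considered here, and "the series" means these few. Any claim that something is new, unique, unknown or untested is made for them only; others in the source may bear on it.

Compound 2, with the structure `Cc1ccc(NC(=O)c2c(NO)cc(-c3ccc(F)cc3)oc2=O)cc1`, stands in an ADME assay on Huh-7 cells (Homo sapiens) for cytotoxicity, read by a luciferase reporter and WST assay, with a stated time of 3 days (a lower number here means that less compound is tolerated, a higher number that more compound is tolerated), only at a limit of the measurement, > 20000 nM. Its parent, compound 1 with the structure `O=C(Nc1ccccc1)c1c(NO)cc(-c2ccc(F)cc2)oc1=O`, gives in this assay a number, 10300 nM. Among the measured compounds shown here, the one measured step, an at least 1.9-fold higher number from compound 1 to compound 2 (0.28 log units; that floor lies within the scatter), rests on the limit of > 20000 nM in this assay, at which 1 of the 2 values shown sits, and so is known only as a floor. Compound 3, with the structure `Cc1ccc(NC(=O)c2c(NO)cc(-c3ccc(C)cc3)oc2=O)cc1`, differs from compound 2 by methyl in place of fluoro on an aromatic carbon. For the measured compounds named here, no measured step touches this ring; the step from compound 1 to compound 2 concerns a methyl on the other aromatic ring, and it does not exceed the scatter. For compound 3 no step beyond the scatter is therefore expected in this assay, and compound 2 already sits at the limit. Compound 3 is estimated at 25000 nM, from 12000 nM to 60000 nM. The expected step is a step that the limit leaves unreadable from compound 2 to compound 3.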

Compound 3, half-maximal cytotoxic concentration: > 20000 nM
Compound 3: no number, only a limit; the forecaster's own chance of this, stated with the estimate: 70%; the middle value lies beyond the limit too.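

In this assay compound 3 stands only at a limit, > 20000 nM. Among the compounds shown here, no step from compound 2 to compound 3 can be read, because both compounds stand at a limit: the limit of > 20000 nM in this assay, at which 2 of the 3 values shown sit. The compounds shown leave open whether methyl in place of fluoro on this ring changes the number in this assay at all.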